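This account rests on a few compounds, and the source may have more. Where it says the series, first, only, none or still open, it means among the compounds named here.

In a functional assay on HeLa cells (Homo sapiens) for inhibition, read by MTT assay, with a stated time of 72 h (on this read-out higher numbers stand for weaker inhibition and lower numbers for stronger inhibition), compound 1 (`Fc1ccc(-c2nnc(SCCCN3CCN(c4nc5ccccc5o4)CC3)o2)cc1`) gives 196000 nM and compound 2 (`Brc1ccc(-c2nnc(SCCCN3CCN(c4nc5ccccc5o4)CC3)o2)cc1`) gives 187000 nM, so compound 2 stands level with compound 1 within the scatter. The unmeasured compound 3 (`O=C(NCc1nnc(SCCCN2CCN(c3nc4ccccc4o3)CC2)o1)c1ccccc1`) carries benzamidomethyl in place of 4-bromophenyl on an aromatic carbon. For the measured compounds named here, only one measured step bears on this change, and only indirectly. The step of a 1.0-fold lower number from compound 1 to compound 2 (0.02 log units; within the scatter) exchanges fluoro for bromo and lies within the scatter. Going by the values given here, it shows that this halogen swap leaves this assay unmoved, but no measured pair replaces the whole 4-bromophenyl group, so the data support no direction. The expected step of a 1.0-fold lower number from compound 2 to compound 3 (0.02 log units; within the scatter) is therefore none beyond the scatter, though with wide uncertainty. The estimate for compound 3 is 180000 nM, with an expected range of 70000 nM to 400000 nM.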

Compound 3, half-maximal inhibitory concentration: 63900 nM
Beside the measured number, compound 3's estimate is 2.8-fold (0.45 log units) above it; measured number outside the range, below it.
By their numbers in this assay, from the lowest: compound 3; then compounds 2 and 1 (each within the scatter of the next).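

In this assay, the group on the aromatic carbon of the five-membered ring does affect the read-out: the swap of fluoro for bromo had shown no step beyond the scatter, but replacing the whole aryl group does, with a 2.9-fold lower number from compound 2 to compound 3 (0.47 log units; beyond the scatter) and a 3.1-fold lower number from compound 1 to compound 3 (0.49 log units; beyond the scatter). The change enters benzamidomethyl, which keeps a six-membered aromatic ring of carbon only while adding a hydrogen-bond donor, a hydrogen-bond acceptor and a double bond outside aromatic rings, so these features change together and the step cannot be assigned to any one of them. No measurement here gives a reason for the step.

As far as these compounds go, whether the amide or the added carbon carries the step remains open, and a plain benzyl group at this place would separate the two. Also open, from the compounds shown here alone, is how the read-out responds to an aminomethyl group or a carboxylic acid there.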